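The compounds below may be only part of what the source reports. "The series", "measured", "known", "first", "only" and "open" are said of these compounds alone.

Compound 1 `Fc1ccc(CSc2nnc(-c3ccncc3)n2-c2ccccc2)c(F)c1`: 10200 nM.
Compound 2 `O=C(CSc1nnc(-c2ccncc2)n1-c1ccccc1)N/N=C/c1ccc(Cl)cc1`: 11000 nM.

In a functional assay on HepG2 cells (Homo sapiens) for inhibition, read by MTT assay, with a stated time of 48 h (on this read-out higher numbers stand for weaker inhibition and lower numbers for stronger inhibition), compound 1 gives 10200 nM and compound 2 gives 11000 nM; the two numbers lie within the scatter of each other, so they cannot be told apart. Compound 3 `O=C(CSc1nnc(-c2ccncc2)n1-c1ccccc1)N/N=C/c1ccc(O)c(O)c1` differs from compound 2 by 3,4-dihydroxyphenyl in place of 4-chlorophenyl on a carbon with a double bond to nitrogen. Within the data shown here, no measured pair shows this kind of change, so no step beyond the scatter is expected in this assay: the expected step is a 1.1-fold lower number from compound 2 to compound 3 (0.04 log units; within the scatter). Compound 3 is therefore expected to give about 10000 nM, somewhere between 3000 nM and 35000 nM.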

Compound 3, half-maximal inhibitory concentration: 16900 nM
Compound 3: middle estimate off by 1.7-fold (0.23 log units), on the low side; measured number inside the range.
By their numbers in this assay, from the lowest: compounds 1, 2 and 3 (each within the scatter of the next).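

In this assay the swap of 4-chlorophenyl for 3,4-dihydroxyphenyl gives a 1.5-fold higher number from compound 2 to compound 3 (0.19 log units; within the scatter) and so leaves the two compounds indistinguishable. For this one pair, a group with hydrogen-bond donors and a group with none read alike at this position on the carbon with a double bond to nitrogen. Nothing on hand offers an explanation for this result. Still open, going by these compounds, is whether a different group here, such as an amine or a carboxylic acid on the phenyl ring, would shift the number beyond the scatter.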